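This account rests on a few compounds, and the source may have more. Where it says the series, first, only, none or still open, it means among the compounds named here.

Measured in a functional assay (Nicotiana tabacum); on this read-out higher numbers stand for weaker inhibition and lower numbers for stronger inhibition:
Compound 1 `CNc1nc(SC)nc2ncccc12`: 2920 nM
Compound 2 `CCCNc1nc(SC)nc2ncccc12`: 270 nM
Compound 3 `CSc1nc(NC2CC2)c2cccnc2n1`: 4900 nM

Compound 3 sits at the weaker end of this small set. Its gap to one neighbour stays within the scatter: a 1.7-fold higher number from compound 1 to compound 3 (0.22 log units; within the scatter). Its gap to the other is large: an 18-fold higher number from compound 2 to compound 3 (1.26 log units; beyond the scatter).

The next compound, compound 4 `CSc1nc(NC2CCC2)c2cccnc2n1`, keeps the shared core and carries cyclobutyl in place of cyclopropyl on a nitrogen on an aromatic ring. Going by the values given here, no measured step makes this exact change, so the evidence is indirect. Going from methyl to propyl on that nitrogen gave an 11-fold lower number from compound 1 to compound 2 (1.03 log units; beyond the scatter), so the group there can move the number a long way. Going from methyl to cyclopropyl gave only a 1.7-fold higher number from compound 1 to compound 3 (0.22 log units; within the scatter), so the data offer no clear trend for rings. A moderate move towards a lower number is expected, though no real change remains possible. For compound 4 the estimated value is 1500 nM, with an expected range of 350 nM to 5000 nM. This estimate means an expected 3.3-fold lower number from compound 3 to compound 4 (0.51 log units; beyond the scatter).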

Compound 4, half-maximal inhibitory concentration: 720 nM
Beside the measured number, compound 4's estimate is 2.1-fold (0.32 log units) above it; the range from low to high includes it.
By their numbers in this assay, from the lowest: compound 2; then compound 4; then compounds 1 and 3 (each within the scatter of the next).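

This result shows that ring size on the nitrogen matters in this assay, since a change as small as cyclobutyl in place of cyclopropyl gives a clear gain (a step of a 6.8-fold lower number from compound 3 to compound 4 (0.83 log units; beyond the scatter)). The earlier compounds shown here gave no sign that a ring could help, as cyclopropyl could not be told apart from methyl; the four-membered ring does better than methyl (a step of a 4.1-fold lower number from compound 1 to compound 4 (0.61 log units; beyond the scatter)), so a ring as such does not decide the outcome. The open propyl chain still holds the lowest number of the set (against the ring, a step of a 2.7-fold higher number from compound 2 to compound 4 (0.43 log units; beyond the scatter)), so the ring recovers much of what the propyl chain gained, but not all of it.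

The compounds shown leave open whether a cyclopentyl ring, or a longer chain such as butyl, on this nitrogen would lower the number further or reverse the trend. No supporting measurement explains why the four-membered ring and the three-membered ring behave so differently.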